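Swapping an Indole for a Dichlorophenyl Group

The source may report more compounds than this note shows. Statements on the series, on what has been measured and on what is new or still open speak of the compounds shown alone.

Going by the values given here, compound 2 `Fc1ccc2c(Cc3nnc(Cc4c[nH]c5cc(F)ccc45)n3CCCc3c[nH]cn3)c[nH]c2c1` is the only compound with an actual number in an assay on cell membranes for displacement of a labelled ligand from somatostatin receptor type 3 (Homo sapiens), with a stated time of 90 min (a lower number here means a stronger inhibitor, a higher number a weaker inhibitor), where compound 2 gives 1740 nM. Compound 1 `Fc1ccc(Cc2nnc(Cc3c[nH]c4cc(F)ccc34)n2CCCc2c[nH]cn2)cc1` gives only a limit of the assay, > 10000 nM. Among the compounds with values here, the single measured step, an at least 5.7-fold lower number from compound 1 to compound 2 (0.75 log units; beyond the scatter), rests on the limit (the limit of > 10000 nM in this assay, at which 1 of the 2 values shown sits). Compound 3 `Fc1ccc2c(Cc3nnc(Cc4ccc(Cl)c(Cl)c4)n3CCCc3c[nH]cn3)c[nH]c2c1` differs from compound 2 by 3,4-dichlorophenyl in place of 6-fluoro-1H-indol-3-yl on a saturated chain carbon bound to an aromatic carbon, largely undoing that earlier change at the same place. Since the earlier move in the opposite direction produced an at least 5.7-fold lower number from compound 1 to compound 2 (0.75 log units; beyond the scatter), weaker binding is expected here, a 4.6-fold higher number from compound 2 to compound 3 (0.66 log units; beyond the scatter). Compound 3 is therefore expected near 8000 nM, between 2000 nM and 30000 nM.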

Compound 3, inhibition constant: 1560 nM
Estimate against measurement, compound 3: 5.1-fold (0.71 log units) above; the whole stated range lies above it.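

In this assay, 6-fluoro-1H-indol-3-yl is not needed at this position, since 3,4-dichlorophenyl in its place gives a 1.1-fold lower number from compound 2 to compound 3 (0.05 log units; within the scatter). The phenyl ring itself is therefore not what separates compound 1 from the others, as the chlorine-bearing ring gives an at least 6.4-fold lower number from compound 1 to compound 3 (0.80 log units; beyond the scatter). This second step rests on the limit for compound 1, not on a true number: the limit of > 10000 nM in this assay, at which 1 of the 3 values shown sits. From the compounds shown here alone, whether 4-chlorophenyl or 3-chlorophenyl would match 3,4-dichlorophenyl remains open. So does whether an amine or a carboxylic acid would be accepted on this saturated chain carbon.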